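Ethyl to Propyl on the Ring Amine: Expected Effect

The source may report more compounds than this note shows. Statements on the series, on what has been measured and on what is new or still open speak of the compounds shown alone.

Compound 3 `CCN1CC[C@@]2(OC)OC(N)=C(C#N)[C@@H](c3ccc(C)cc3)[C@@H]2C1` gives 16800 nM in a functional assay on trachea (Cavia porcellus) (a lower number here means a stronger inhibitor, a higher number a weaker inhibitor), the lowest of the three numbers, though its gaps to compound 1 and to compound 2 both lie within the scatter. Going by the values given here, compound 1 `CCCN1CC[C@@]2(OC)OC(N)=C(C#N)[C@@H](c3ccccc3)[C@@H]2C1` gives 20700 nM, and compound 2 `CCCN1CC[C@@]2(OC)OC(N)=C(C#N)[C@@H](c3ccc(F)cc3)[C@@H]2C1` gives 29600 nM; the step of a 1.4-fold higher number from compound 1 to compound 2 (0.16 log units; within the scatter) is the only measured single change. Compound 4 `CCCN1CC[C@@]2(OC)OC(N)=C(C#N)[C@@H](c3ccc(C)cc3)[C@@H]2C1` differs from compound 3 by methyl in place of hydrogen on a saturated chain carbon, two bonds along the chain from an amine nitrogen in a ring. Among the compounds with values here, no measured pair bears directly on this change: compound 1 and compound 2 already carry the propyl, and the fluoro step does not touch it. Compound 4 is therefore expected to show no step beyond the scatter, a 1.1-fold higher number from compound 3 to compound 4 (0.03 log units; within the scatter). The estimate for compound 4 in this assay is 18000 nM, from 8000 nM to 40000 nM.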

Compound 4, half-maximal inhibitory concentration: 21000 nM
For compound 4 the middle estimate is 1.2-fold (0.07 log units) below the measured one; low and high end bracket the measured number.
By their numbers in this assay, from the lowest: compounds 3, 1, 4 and 2 (each within the scatter of the next).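

In this assay, going by these compounds alone, the first measured step at this position, a 1.3-fold higher number from compound 3 to compound 4 (0.10 log units; within the scatter), shows that methyl in place of hydrogen on this saturated chain carbon, turning ethyl into propyl, stays within the scatter. With the propyl in place, the aromatic carbon also stays within the scatter, with methyl in place of fluoro giving a 1.4-fold lower number from compound 2 to compound 4 (0.15 log units; within the scatter) and methyl in place of hydrogen giving a 1.0-fold higher number from compound 1 to compound 4 (0.01 log units; within the scatter). Nothing available explains these results. From the compounds shown here alone, whether a longer chain such as butyl on the ring nitrogen would stay within the scatter remains open. So does the effect of a methoxy group on the aromatic carbon.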